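Ring methyl position in the shared core series

The source may hold more compounds than are shown below. What is called first, only, known or untested is meant among the compounds shown, and "the series" means these compounds.

In a functional assay on A-431 cells (Homo sapiens) for cytotoxicity, read by MTT assay, with a stated time of 72 h, tested at 1 uM (a lower number here means less inhibition of growth, a higher number more inhibition of growth at the concentration tested), compound 1 `N/C(=N\NC(=S)N1CCOCC1)c1ccccn1` gives 29.2%, numerically the lowest of the three measured numbers, although all three lie within the scatter of one another. Compound 3 `N/C(=N\NC(=S)N1CCSCC1)c1ccccn1` gives 31.7%, and compound 2 `Cc1ccnc(/C(N)=N/NC(=S)N2CCOCC2)c1` gives 33.6%. Neither single change moved the read-out beyond the scatter: a number 2.5 percentage points higher from compound 1 to compound 3 (within the scatter), and a number 4.4 percentage points higher from compound 1 to compound 2 (within the scatter).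

Compound 4 `Cc1cccc(/C(N)=N/NC(=S)N2CCOCC2)n1` differs from compound 1 by methyl in place of hydrogen on an aromatic carbon. Going by the values given here, the only measured step that bears on this change is the one in which the same group enters the same ring at a different carbon, from compound 1 to compound 2, and that step stayed within the scatter. Among the compounds with values here, no measured compound carries a methyl at the position now in question, so the comparison rests on that single step alone. A step within the scatter, in no particular direction, is therefore expected in this assay. Compound 4 is expected to give 31% in this assay, with a range from 21% to 42%, meaning an estimated step of a number 1.8 percentage points higher from compound 1 to compound 4 (within the scatter).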

Compound 4, percent growth inhibition at one concentration: 47.2%
For compound 4 the middle estimate is 16.2 percentage points below the measured one; the whole stated range lies below it.
By their numbers in this assay, from the lowest: compounds 1, 3 and 2 (each within the scatter of the next); then compound 4.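

In this assay, methyl in place of hydrogen on the aromatic carbon next to the ring nitrogen gives a number 18 percentage points higher from compound 1 to compound 4 (beyond the scatter), so this position responds to the change at the concentration tested. The same group at a different ring carbon gave a number 4.4 percentage points higher from compound 1 to compound 2 (within the scatter), so among these compounds the outcome of the change depends on where the methyl sits. No available data bear on the reason for this difference.

Going by these compounds, it remains open whether an ethyl group, an amine or a carboxylic acid at this same carbon would give a number like that of compound 4. On these data alone, it is also open whether the methyl at this carbon would have the same effect alongside the thiomorpholin-4-yl group of compound 3.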